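Trading a long ether chain for isopropyl

A few compounds are considered here, and "the series" means these few. Any claim that something is new, unique, unknown or untested is made for them only; others in the source may bear on it.

In an ADME assay on RAW264.7 cells (Mus musculus) for cytotoxicity, read by MTT assay, with a stated time of 24 h (a lower number here means that less compound is tolerated, a higher number that more compound is tolerated), compound 3 `CC/C=C\C[C@H]1C(=O)C=C[C@H]1CC(=O)OCCOCCOC` gives 161 uM. Compound 2 `CC/C=C\C[C@H]1C(=O)C=C[C@H]1CC(=O)OCCO` gives 161 uM, level with it, and together they hold the highest of the three numbers. Compound 1 `CC/C=C\C[C@H]1C(=O)C=C[C@H]1CC(=O)OCCCC` sits lowest at 31 uM.

Compound 4 `CC/C=C\C[C@H]1C(=O)C=C[C@H]1CC(=O)OC(C)C` differs from compound 3 by one change, isopropyl in place of 2-(2-methoxyethoxy)ethyl on an oxygen next to a carbonyl group. Like isopropyl, the chain on that oxygen in compound 1 contains no oxygen, whereas the chains in the other two compounds do. Two measured steps therefore bear on the change: a 5.2-fold higher number from compound 1 to compound 2 (0.72 log units; beyond the scatter) and a 5.2-fold higher number from compound 1 to compound 3 (0.72 log units; beyond the scatter). Both are modest, and a third step shows that chain length among the oxygen-bearing chains made no visible difference: no change at the digits printed from compound 2 to compound 3 (within the scatter).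

Isopropyl is not the same chain as the one in compound 1, so only part of that size is expected, in the downward direction. The expected step is a 2.3-fold lower number from compound 3 to compound 4 (0.36 log units; beyond the scatter). For compound 4 the estimate is 70 uM, with an expected range of 30 uM to 160 uM.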

Compound 4, half-maximal toxic concentration: 58 uM
Beside the measured number, compound 4's estimate is 1.2-fold (0.08 log units) above it; the range from low to high includes it.
By their numbers in this assay, from the lowest: compounds 1 and 4 (each within the scatter of the next); then compounds 2 and 3 (each within the scatter of the next).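

In this assay, isopropyl on this oxygen falls with butyl rather than with the chains that contain oxygen: the change gives a 2.8-fold lower number from compound 3 to compound 4 (0.44 log units; beyond the scatter) and a 2.8-fold lower number from compound 2 to compound 4 (0.44 log units; beyond the scatter), whereas a 1.9-fold higher number from compound 1 to compound 4 (0.27 log units; within the scatter) is a step too small to rank the two. Among these four compounds, the numbers therefore form two pairs, with the oxygen-free chains of compound 1 and compound 4 on the lower side and the oxygen-bearing chains of compound 2 and compound 3 on the higher side, and no compound here goes against that split. Nothing measured here explains the split.

As far as these compounds go, whether the split holds beyond these four esters remains open. A chain ending in an amine or a carboxylic acid, or a longer branched chain without oxygen, could test it.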